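Compound 4 against a series sitting at the limit

The compounds below may be only part of what the source reports. "The series", "measured", "known", "first", "only" and "open" are said of these compounds alone.

Working notes on the series in a functional assay on SW1573 cells (Homo sapiens) for antiproliferative activity, read by sulforhodamine B assay, with a stated time of 48 h; on this read-out lower numbers stand for stronger inhibition of growth and higher numbers for weaker inhibition of growth. Compound 1 `CC(C)(C)[Si](C)(C)O[C@@H]1CCCO[C@@H]1CO` gives > 100000 nM, which is a limit of the assay and not a number. Compound 2 `O=C(COC[C@H]1OCCC[C@@H]1O)OCc1ccccc1` gives > 100000 nM, again a limit. Compound 3 `O=C1COC[C@H]2OCCC[C@@H]2O1` gives > 100000 nM, also a limit. Compound 1 therefore has no number to stand on and no rank among the others, and the whole picture reads: the limit of > 100000 nM in this assay, at which 3 of the 3 values shown sit. For the measured compounds named here, no measured step exists within this set.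

The next compound is compound 4 `COC(=O)CCOC[C@H]1OCCC[C@H]1O[Si](C)(C)C(C)(C)C`. Its change from compound 1 is 2-(methoxycarbonyl)ethyl in place of hydrogen on an oxygen on a saturated carbon. In words, 2-(methoxycarbonyl)ethyl stands in place of hydrogen on an oxygen on a saturated carbon, so hydroxy becomes 2-(methoxycarbonyl)ethoxy.

With nothing measured to size this change, only a small effect is expected in this assay, if any, and it is expected to point towards stronger inhibition of growth. The starting point for that expectation is compound 1 at > 100000 nM, a limit. The estimated size is an at least 1.4-fold lower number from compound 1 to compound 4 (0.15 log units; that floor lies within the scatter), and a report of the same limit is expected to be at least as likely as a number. For compound 4 the estimated value is 70000 nM, with an expected range from 20000 nM to 100000 nM.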

Compound 4, concentration for 50% growth inhibition: > 100000 nM
Compound 4: no number, only a limit; the forecaster's own chance of this, stated with the estimate: 60%; at least 1.4-fold (0.15 log units) between middle value and limit.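

For the compounds shown here, compound 1 and compound 4 both sit at a limit of the assay, so the change from hydroxy to 2-(methoxycarbonyl)ethoxy gives no step that can be read. The series stands as follows: the limit of > 100000 nM in this assay, at which 4 of the 4 values shown sit.

The compounds shown leave open whether any change to the shared core gives a measurable number.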